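Swapping Methoxy for Fluoro in a Rapidly Cleared Series

A few compounds are considered here, and "the series" means these few. Any claim that something is new, unique, unknown or untested is made for them only; others in the source may bear on it.

In an in vitro ADME assay on microsomes from liver (Mus musculus) for pharmacokinetics, read by LC-MS (a lower number here means slower removal, a higher number faster removal of the compound), compound 1 (`Cc1cccc2c1nc(C)n2-c1ccc(C(=O)NC2CC2)s1`) gives 66 mL/min/kg and compound 2 (`Cc1nc2ccc(C(F)(F)F)cc2n1-c1ccc(C(=O)NC2CC2)s1`) gives 68 mL/min/kg, two values within the usual scatter of each other. Compound 3 (`COc1cccc2c1nc(C)n2-c1ccc(C(=O)NC2CC2)s1`) reads > 72 mL/min/kg, which is a limit of the assay and not a number. Its true position is therefore not known exactly.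

Compound 4 (`Cc1nc2c(F)cccc2n1-c1ccc(C(=O)NC2CC2)s1`) is the next one to test, and it differs from compound 3 as follows: fluoro in place of methoxy on an aromatic carbon. In short, fluoro takes the place of methoxy on an aromatic carbon.

Among the compounds with values here, only one measured step bears on this, methoxy in place of methyl on an aromatic carbon, and it shows an at least 1.0-fold higher number from compound 1 to compound 3 (0.03 log units; that floor lies within the scatter). That step gives no sign that this group matters much in this assay, so no clear change beyond the scatter is expected, though a modest drop is possible. The expected step is an at least 1.2-fold lower number from compound 3 to compound 4 (0.07 log units; that floor lies within the scatter). For compound 4 the estimate is 60 mL/min/kg, with an expected range from 38 mL/min/kg to 72 mL/min/kg.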

Compound 4, clearance: 37 mL/min/kg
Beside the measured number, compound 4's estimate is 1.6-fold (0.21 log units) above it; the whole stated range lies above it.
By their numbers in this assay, from the lowest: compounds 4, 1 and 2 (each within the scatter of the next). At a limit, above all of these: compound 3.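

In this assay the group on this aromatic carbon is now compared directly with methyl: fluoro gives a 1.8-fold lower number from compound 1 to compound 4 (0.25 log units; within the scatter) and so cannot be told apart from methyl at this position. Set against methoxy, fluoro gives an at least 1.9-fold lower number from compound 3 to compound 4 (0.28 log units; that floor lies within the scatter) and this is the first hint that the group here can move the number, although that floor does not clear the scatter. Compound 3 has a limit and not a number, so the true size of that step stays unknown because of where compound 3 sits: the limit of > 72 mL/min/kg in this assay, at which 1 of the 4 values shown sits.

As far as these compounds go, whether another group on this carbon, such as an amine or a nitrile, would shift the clearance beyond the scatter remains open. Also open, from the compounds shown here alone, is whether chloro, a close relative of fluoro, would read like compound 4 or differ from it.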